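The compounds below may be only part of what the source reports. "The series", "measured", "known", "first", "only" and "open" are said of these compounds alone.

Compound 1 `CCN(CC)c1ccc(-c2cccc(C(F)(F)F)c2)nn1`: > 25000 nM, a limit
Compound 2 `CCOC(=O)c1cccc(-c2ccc(N(CC)CC)nn2)c1`: > 25000 nM, a limit

In an ADME assay on cells (Fibroblast, Homo sapiens) for antiproliferative activity, with a stated time of 48 h (a higher number here means a weaker inhibitor, a lower number a stronger inhibitor), compound 1 stands only at a limit, > 25000 nM. The evidence so far is the limit of > 25000 nM in this assay, at which 2 of the 2 values shown sit. Compound 3 `CN1CCN(c2ccc(-c3cccc(C(F)(F)F)c3)nn2)CC1` differs from compound 1 in one group: 4-methylpiperazin-1-yl in place of diethylamino on an aromatic carbon. Going by the values given here, the only measured step, a step that the two limits leave unreadable from compound 1 to compound 2, changes a different group and has no readable size, so it sets no size here. No readable step is therefore expected in this assay, and any measurable shift could only be toward stronger inhibition. The expected step is a number no higher from compound 1 to compound 3 (the limit leaves the size open). Compound 3 is estimated at 25000 nM, with an expected range of 10000 nM to 40000 nM.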

Compound 3, half-maximal inhibitory concentration: > 25000 nM
Compound 3: a limit, no number; the forecaster's own chance of this, stated with the estimate: 70%; the middle value lies on the limit itself.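

Compound 1 and compound 3 both sit only at a limit in this assay, so no step can be read between them. The compounds shown leave open how any change on the shared core alters activity, the only reading so far being: the limit of > 25000 nM in this assay, at which 3 of the 3 values shown sit.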